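This account rests on a few compounds, and the source may have more. Where it says the series, first, only, none or still open, it means among the compounds named here.

The shared core of this set is varied at the benzyl group attached to it. Among the compounds with values here, compound 1 `CC(C)Cn1c(=O)c2nc(-c3cnn(Cc4cccc(F)c4)c3)[nH]c2n(CC(C)C)c1=O` is the one member with a number: in an assay on CHO cells for displacement of a labelled ligand from adenosine receptor A1 (Homo sapiens) (a lower number here means a stronger inhibitor, a higher number a weaker inhibitor), compound 1 gives 830 nM. Compound 2 `CCCn1c(=O)c2nc(-c3cnn(Cc4c(F)cccc4F)c3)[nH]c2n(CCC)c1=O` stands apart from it in more than one place, and in this assay compound 2 gives "not determined" (no result reported), so it stands without any number; in this assay compound 3 `CCCn1c(=O)c2nc(-c3cnn(Cc4cc(C(F)(F)F)cc(Cl)c4F)c3)[nH]c2n(CCC)c1=O` likewise gives "not determined" (no result reported), so nothing can be said of how compound 2 compares with either neighbour.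

Compound 4 `CCCn1c(=O)c2nc(-c3cnn(Cc4ccccc4OC)c3)[nH]c2n(CCC)c1=O` is the unmeasured step from compound 2. The difference is 2-methoxyphenyl in place of 2,6-difluorophenyl on a saturated chain carbon bound to an aromatic nitrogen. Both groups have the same number of heavy atoms and one six-membered aromatic ring, and the change sits on a saturated chain carbon bound to an aromatic nitrogen, away from the core. Within the data shown here, with no measured step recorded between any two compounds, no direction can be read off, and the step from compound 2 to compound 4 in this assay is expected to be small, likely within the scatter. Compound 4 is therefore estimated at 1000 nM, with a range from 200 nM to 5000 nM, anchored loosely on compound 1.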

Compound 4, inhibition constant: 59 nM
Compound 4: middle estimate off by 17-fold (1.23 log units), on the high side, and the stated range ends above it.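

No new step can be read from compound 4: compound 2 stands without a number, and compound 1 differs from compound 4 in more than one place. The compounds shown leave open how much swapping one benzyl group for another changes the inhibition on its own. Nothing shown explains the value of compound 4.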